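A few compounds are considered here, and "the series" means these few. Any claim that something is new, unique, unknown or untested is made for them only; others in the source may bear on it.

Working notes on the series. Compound 1 `O=C(NCc1ccc(OCc2ccc(-c3nn[nH]n3)cc2)cc1)[C@@H]1CCC(=O)N1Cc1ccccc1` and compound 2 `O=C(NCc1ccc(O)cc1)[C@@H]1CCC(=O)N1Cc1ccccc1` share one core. In an assay on HEK293 cells for inhibition of Ataxin-2 (Mus musculus), read by fluorescence and Amplex Red (a lower number here means a stronger inhibitor, a higher number a weaker inhibitor), compound 1 gives only a limit, > 5000 nM. In this assay compound 2 likewise gives only a limit, > 5000 nM. The step that the two limits leave unreadable from compound 1 to compound 2 therefore cannot be read, because both values sit at the limit of > 5000 nM in this assay, at which 2 of the 2 values shown sit.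

Compound 3 `O=C(NCc1ccc(OCc2cn(-c3ccccc3)nn2)cc1)[C@@H]1CCC(=O)N1Cc1ccccc1` differs from compound 2 by (1-phenyl-1H-1,2,3-triazol-4-yl)methyl in place of hydrogen on an oxygen on an aromatic ring. Within the data shown here, the only measured step that bears on this change is the unreadable one from compound 1 to compound 2, which concerns a substituent on the same oxygen and gives neither a size nor a direction. Among the measured compounds shown here, compound 3 carries a group of similar extent to the one in compound 1, whose reading is a limit, so nothing beyond the scatter is expected and a further limit is the likeliest outcome. The estimate for compound 3 in this assay is 8000 nM, between 3000 nM and 30000 nM. The step that the limit leaves unreadable from compound 2 to compound 3 that this estimate implies is expected to stay within the scatter.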

Compound 3, half-maximal inhibitory concentration: > 5000 nM
Compound 3: a limit, no number; the forecaster's own chance of this, stated with the estimate: 75%; the middle value does not contradict the limit.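

In this assay, among these compounds, compound 3 gives > 5000 nM as a limit, and no step among compound 1, compound 2 and compound 3 can be read: the limit of > 5000 nM in this assay, at which 3 of the 3 values shown sit. The compounds shown leave open whether any substituent on this oxygen on an aromatic ring changes inhibition.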